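A few compounds are considered here, and "the series" means these few. Any claim that something is new, unique, unknown or untested is made for them only; others in the source may bear on it.

In an ADME assay on HEp-2 cells (Homo sapiens) for cytotoxicity, read by MTT assay, with a stated time of 72 h (on this read-out lower numbers stand for stronger inhibition and higher numbers for weaker inhibition), the measured compounds stand as follows:

- compound 1 `COc1ccc(C2=C(c3cc(OC)c(OC)c(OC)c3)C(=O)CC2O[SiH2]C(C)(C)C)cc1OC` gives > 100 ug/mL (a limit)
- compound 2 `COc1ccc(C2=C(c3cc(OC)c(OC)c(OC)c3)C(=O)CC2O)cc1O` gives < 1 ug/mL (a limit)
- compound 3 `COc1ccc(C2=C(c3cc(OC)c(OC)c(OC)c3)C(=O)CC2O)cc1` gives > 100 ug/mL (a limit)

Compound 2 stands at the low end of the numbers shown, with the limit of < 1 ug/mL in this assay, at which 1 of the 3 values shown sits, so it has a limit and no exact number. Compound 1 and compound 3 both stand at the other end, with the limit of > 100 ug/mL in this assay, at which 2 of the 3 values shown sit.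

Compound 4 `COc1ccc(C2=C(c3cc(OC)c(OC)c(OC)c3)C(=O)CC2O[SiH2]C(C)(C)C)cc1O` keeps the aromatic hydroxy of compound 2 and differs from it by a group of 5 heavy atoms (4 carbon, 1 silicon; no ring) in place of a hydrogen atom, on an oxygen on a saturated carbon. Going by the values given here, the only measured step is an at least 100-fold higher number from compound 2 to compound 3 (2.00 log units; beyond the scatter), which is large and beyond the scatter. It lies at the aromatic hydroxy, however, and so does not size the change at the oxygen on the saturated carbon. Compound 1 carries the same group in that place and gives > 100 ug/mL, which is a limit. Compound 1 also lacks the aromatic hydroxy, so that limit cannot be assigned to the group alone.

A moderate move to a higher number is expected in this assay, with less loss than at the aromatic hydroxy, because compound 4 retains the hydroxy that is lost in an at least 100-fold higher number from compound 2 to compound 3 (2.00 log units; beyond the scatter). Compound 4 is estimated at 5 ug/mL, with an expected range from 0.5 ug/mL to 50 ug/mL. The expected size is an at least 5.0-fold higher number from compound 2 to compound 4 (0.69 log units; beyond the scatter) for this change.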

Compound 4, half-maximal inhibitory concentration: 14.5 ug/mL
The estimate for compound 4 lay 2.9-fold (0.46 log units) below the measured number, within the range that was stated.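

In this assay the oxygen on the saturated carbon proves to be a place that responds to change: the group of 5 heavy atoms (4 carbon, 1 silicon; no ring) in place of a hydrogen atom gives an at least 14-fold higher number from compound 2 to compound 4 (1.16 log units; beyond the scatter). The aromatic hydroxy still counts with that group in place, as hydrogen in place of methyl on an oxygen on an aromatic ring gives an at least 6.8-fold lower number from compound 1 to compound 4 (0.83 log units; beyond the scatter), so the group alone does not account for the limit seen with compound 1. Compound 4 keeps an exact number and so stands apart from the two compounds at the upper end of the series: the limit of > 100 ug/mL in this assay, at which 2 of the 4 values shown sit.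

As far as these compounds go, compound 2 gives < 1 ug/mL, which is a limit, and the full size of the step at the oxygen on the saturated carbon stays open. Also open, from the compounds shown here alone, is whether that step depends on the size of the entering group or on the loss of the free hydroxy, a question that a methyl ether or an acetyl ester on that oxygen, or an amine in its place, would address.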